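The source may report more compounds than this note shows. Statements on the series, on what has been measured and on what is new or still open speak of the compounds shown alone.

Working notes on the series in an ADME assay on microsomes from liver (Homo sapiens) for metabolic stability; a higher number here means faster removal of the compound, a lower number slower removal. Compound 1 (`CCn1cnc2c(-c3ccc(F)c(-c4cc(C#N)ccc4OC)c3)cnnc21`) gives 66 mL.min-1.g-1, compound 2 (`CCn1cnc2c(-c3ccc(F)c(-c4ccc(C#N)cc4OC)c3)cnnc21`) gives 32 mL.min-1.g-1, and compound 3 (`CCn1cnc2c(-c3ccc(F)c(-c4ccc(S(=O)(=O)C(C)C)cc4OC)c3)cnnc21`) gives 84 mL.min-1.g-1. Compound 3 thus stands level with compound 1, within the scatter, and beyond the scatter from compound 2.

The next compound is compound 4 (`CCn1cnc2c(-c3ccc(F)c(-c4ccc(S(=O)(=O)C5COC5)cc4OC)c3)cnnc21`), which has oxetan-3-yl in place of isopropyl on a sulfonyl sulfur.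

For the measured compounds named here, one measured step bears on this change, and only indirectly: a 2.6-fold higher number from compound 2 to compound 3 (0.42 log units; beyond the scatter). That step is modest, and it replaces a whole group on an aromatic carbon. Going by the values given here, no measured pair changes only the group on the sulfonyl sulfur, so the direction here is a judgement from the structural change alone. In this assay, a step no larger than that one is expected, towards a lower number, and it may stay inside the scatter. The estimated step is a 1.9-fold lower number from compound 3 to compound 4 (0.27 log units; within the scatter). Compound 4 is estimated at 45 mL.min-1.g-1, with an expected range of 22 mL.min-1.g-1 to 85 mL.min-1.g-1.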

Compound 4, intrinsic clearance in microsomes in the Homo sapiens assay: 67 mL.min-1.g-1
Estimate against measurement, compound 4: 1.5-fold (0.17 log units) below; measured number inside the range.
By their numbers in the Homo sapiens assay, from the lowest: compound 2; then compounds 1, 4 and 3 (each within the scatter of the next).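

For the compounds shown here, this is the only measured change on the sulfonyl sulfur itself, and in the Homo sapiens assay it gives no step that can be told from the scatter: a 1.3-fold lower number from compound 3 to compound 4 (0.10 log units; within the scatter). The (oxetan-3-yl)sulfonyl group also stays apart from the cyano group, with a step beyond the scatter: a 2.1-fold higher number from compound 2 to compound 4 (0.32 log units; beyond the scatter). In a physicochemical assay for lipophilicity (a higher number here means a more lipophilic compound, a lower number a more polar compound), the same change does move the number, with compound 3 at 3 and compound 4 at 2.2 and thus on this pair a shift in distribution coefficient beyond the scatter comes without a matching shift in removal from microsomes: the measured distribution coefficient of compound 3, 3, and of compound 4, 2.2, a number 0.80 log units lower (beyond the scatter).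

From the compounds shown here alone, whether a methyl, a cyclopropyl or an amine on the sulfonyl sulfur would bring the number closer to that of compound 2 stays open. With a single pair at this position, no trend with group size or ring can be read.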